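Ethyl for Nitro on the Amide-Side Ring

The source may report more compounds than this note shows. Statements on the series, on what has been measured and on what is new or still open speak of the compounds shown alone.

Measured so far:
Compound 1, `O=C(CSc1nc(Nc2ccccc2)c2ccccc2n1)Nc1cccc(Cl)c1`, gives 8460 nM in a functional assay on NCI-H1975 cells (Homo sapiens) for inhibition, read by MTT assay, with a stated time of 72 h; on this read-out lower numbers stand for stronger inhibition and higher numbers for weaker inhibition.
Compound 2, `O=C(CSc1nc(Nc2ccccc2)c2ccccc2n1)Nc1ccc([N+](=O)[O-])cc1`, gives 13000 nM in this assay.

Within the data shown here, compound 2 holds the highest of the two numbers, its nearest neighbour being compound 1, but the one step recorded, a 1.5-fold higher number from compound 1 to compound 2 (0.19 log units; within the scatter), is within the scatter, so the two compounds cannot be told apart on these data.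

Compound 3, `CCc1ccc(NC(=O)CSc2nc(Nc3ccccc3)c3ccccc3n2)cc1`, has not yet been measured. It differs from compound 2 by ethyl in place of nitro on an aromatic carbon. Among the measured compounds shown here, the only measured step, from compound 1 to compound 2, concerns a different exchange at the same ring and was small; no measured pair shows what an ethyl group does there. With so thin a basis, the expectation is that compound 3 stays close to compound 2, with a step of a 1.3-fold lower number from compound 2 to compound 3 (0.11 log units; within the scatter) and no clear direction beyond the scatter. Compound 3 is therefore estimated at 10000 nM in this assay, with a plausible range from 3000 nM to 35000 nM.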

Compound 3, half-maximal inhibitory concentration: 9910 nM
Compound 3: middle estimate off by 1.0-fold (0.00 log units), on the high side; the range from low to high includes it.
By their numbers in this assay, from the lowest: compounds 1, 3 and 2 (each within the scatter of the next).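

In this assay, putting ethyl in place of nitro swaps a group with hydrogen-bond acceptors for one without any, yet it gives a 1.3-fold lower number from compound 2 to compound 3 (0.12 log units; within the scatter), so this position does not separate the two groups on these data. Among these compounds, the second comparison, a 1.2-fold higher number from compound 1 to compound 3 (0.07 log units; within the scatter), is also within the scatter, which means that 3-chlorophenyl, 4-nitrophenyl and 4-ethylphenyl on the amide nitrogen cannot be told apart, whereas the earlier pair covered only two of these rings. No separate measurement accompanies these numbers that could account for how closely they agree.

Going by these compounds, it remains open whether any group on this ring can shift the number beyond the scatter, for example an amine, a carboxylic acid or a longer chain in the place held by ethyl. On these data alone, the shared core and the phenyl on its amino group are the same in all three compounds, so what changes there would do also remains unknown.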